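Removing one fluoro from the benzyl group of compound 1

The source may report more compounds than this note shows. Statements on the series, on what has been measured and on what is new or still open speak of the compounds shown alone.

Values in a functional assay on A-375 cells (Homo sapiens) for activation, with a stated time of 3 days; a higher number here means that more compound is needed for the effect, a lower number that less compound is needed:
- compound 1 `O=C(Nc1ccc(-c2cscn2)cc1)C1CCCN(Cc2ccc(F)c(F)c2)C1`: 1240 nM
- compound 2 `O=C(Nc1ccc(-c2cscn2)cc1)C1CN(Cc2ccc(F)c(F)c2)C1`: > 20000 nM (a limit of the assay, not a number)
- compound 3 `O=C(Nc1ccc(-c2cscn2)cc1)[C@H]1CCCN(Cc2ccc(F)c(F)c2)C1`: 270 nM

Compound 1 carries the higher of the two numeric values in this assay, and compound 3 is its nearest neighbour. Compound 2 is reported only as a limit, (the limit of > 20000 nM in this assay, at which 1 of the 3 values shown sits).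

The next comparison is compound 4 `O=C(Nc1ccc(-c2cscn2)cc1)C1CCCN(Cc2ccc(F)cc2)C1` against compound 1. The change is hydrogen in place of fluoro on an aromatic carbon, ortho to a fluoro group and meta to a large group, so that 3,4-difluorobenzyl becomes 4-fluorobenzyl.

Within the data shown here, no measured step touches this position. The only one available, a 4.6-fold lower number from compound 1 to compound 3 (0.66 log units; beyond the scatter), is modest and sits elsewhere, at the saturated ring carbon (the fact that one of compounds 1 and 3 is drawn with a defined configuration and the other without, at the place where they differ). It therefore gives no size for the fluoro change. Compound 4 is drawn without a configuration at that carbon, as compound 1 is, so compound 1 remains the fair reference.

Among the measured compounds shown here, with no direct precedent, no shift beyond the scatter is expected, though the uncertainty is wide. The expected change is a 1.2-fold higher number from compound 1 to compound 4 (0.08 log units; within the scatter). For compound 4 the estimated value is 1500 nM, with an expected range of 500 nM to 5000 nM.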

Compound 4, half-maximal effective concentration: 5000 nM
The estimate for compound 4 lay 3.3-fold (0.52 log units) below the measured number, and the stated range covers the measured number.
By their numbers in this assay, from the lowest: compound 3; then compound 1; then compound 4. At a limit, above all of these: compound 2.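

In this assay, the fluoro on the aromatic carbon, ortho to a fluoro group and meta to a large group, proves not to be interchangeable with hydrogen: going from 3,4-difluorobenzyl to 4-fluorobenzyl gives a 4.0-fold higher number from compound 1 to compound 4 (0.61 log units; beyond the scatter). Among these compounds, this is the first measured step on the benzyl group, since the only earlier step, a 4.6-fold lower number from compound 1 to compound 3 (0.66 log units; beyond the scatter), sits at the saturated ring carbon, and it shows that a change of a single fluorine atom at this position is enough to move the number beyond the scatter, with both compounds drawn without a configuration at that ring carbon. Nothing available explains this step, as the evidence at hand concerns other features of the series.

Among the compounds shown here, still open is whether the step carries over to the defined configuration of compound 3, as the only measured fluoro change is on compounds drawn without one. Also open, from the compounds shown here alone, is how far the effect is tied to fluoro itself, which a chloro or methyl group in the same place, or an unsubstituted benzyl group, would help to settle.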